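The source may hold more compounds than are shown below. What is called first, only, known or untested is meant among the compounds shown, and "the series" means these compounds.

Measured so far in a functional assay on 143B cells (Homo sapiens) for antiproliferative activity, read by MTT assay, with a stated time of 48 h; a lower number here means a stronger inhibitor, a higher number a weaker inhibitor:
Compound 1, `O=C(Nc1cccc(/C=C/C(=O)c2nc3ccccc3[nH]2)c1)c1cccc(Cl)c1`, gives 3370 nM.
Compound 2, `Cc1ccc(C(=O)Nc2cccc(/C=C/C(=O)c3nc4ccccc4[nH]3)c2)cc1`, gives 6560 nM.

Only these two compounds of the shared core carry numbers in this assay, and the single step between them, a 1.9-fold higher number from compound 1 to compound 2 (0.29 log units; within the scatter), lies within the scatter, so compound 2 cannot be told apart from compound 1 on the numbers shown.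

Compound 3, `COc1ccc(C(=O)Nc2cccc(/C=C/C(=O)c3nc4ccccc4[nH]3)c2)cc1`, has not been measured. It differs from compound 2 in one place: methoxy in place of methyl on an aromatic carbon. Among the measured compounds shown here, no measured step bears directly on a methoxy against a methyl on this ring. For the measured compounds named here, the only measured step, which swaps one aryl group on the carbonyl carbon for another, stayed within the scatter, so a change confined to a single substituent on that same ring is expected to do no more. For compound 3 the expected step is a 1.2-fold lower number from compound 2 to compound 3 (0.08 log units; within the scatter), that is, no change beyond the scatter in this assay. Compound 3 is therefore estimated at 5500 nM, with a range of 2000 nM to 15000 nM.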

Compound 3, half-maximal inhibitory concentration: 6330 nM
The estimate for compound 3 lay 1.2-fold (0.06 log units) below the measured number, within the range that was stated.
By their numbers in this assay, from the lowest: compounds 1, 3 and 2 (each within the scatter of the next).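

In this assay, methoxy in place of methyl on an aromatic carbon para to a large group gives a 1.0-fold lower number from compound 2 to compound 3 (0.02 log units; within the scatter) and so adds an oxygen and a hydrogen-bond acceptor with no change beyond the scatter. The exchange of 3-chlorophenyl for 4-methoxyphenyl on the carbonyl carbon gives a 1.9-fold higher number from compound 1 to compound 3 (0.27 log units; within the scatter) and likewise stays within the scatter, so 3-chlorophenyl, 4-methylphenyl and 4-methoxyphenyl cannot be told apart in these numbers. No evidence accompanying these compounds accounts for this result.

Still open, from the compounds shown here alone, is whether an amine, a carboxylic acid or a longer chain such as butoxy at the same place would move the number beyond the scatter. Also open, going by these compounds, is whether any change to the shared core itself would do so.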